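This account rests on a few compounds, and the source may have more. Where it says the series, first, only, none or still open, it means among the compounds named here.

Working notes on the series. In a functional assay on the whole organism for inhibition, with Lemna aequinoctialis as the target, with a stated time of 7 days, tested at 50 ug/mL (on this read-out higher numbers stand for more inhibition of growth at the one concentration tested and lower numbers for less inhibition of growth), compound 1 `O=C1Nc2ccc(F)cc2/C1=N/NC(=S)Nc1ccccc1` gives 15% and compound 2 `O=C1Nc2ccc(F)cc2/C1=N/NC(=S)Nc1ccc(F)cc1F` gives 20% which places compound 2 within the scatter of compound 1, so no order can be drawn between the two. The next structure is compound 3 `O=C1Nc2ccc(F)cc2/C1=N/NC(=S)Nc1c(F)cccc1F` with 2,6-difluorophenyl in place of 2,4-difluorophenyl on an amide-type nitrogen as the counted difference: 2,6-difluorophenyl in place of 2,4-difluorophenyl on an amide-type nitrogen, the same atoms joined differently. Among the compounds with values here, one measured step bears on this change, a number 5 percentage points higher from compound 1 to compound 2 (within the scatter) and it stays within the scatter. Within the data shown here, no measured compound carries 2,6-difluorophenyl, so the data give no direct reading on that group. With compound 2 at 20% as the starting point, no step beyond the scatter is expected in this assay for this change. The expected step is a number 2 percentage points lower from compound 2 to compound 3 (within the scatter) and this lies within the scatter. Compound 3 is estimated at 18% with an expected range from 5% to 35% on this read-out.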

Compound 3, percent growth inhibition at one concentration: 10%
Beside the measured number, compound 3's estimate is 8 percentage points above it, and the stated range covers the measured number.
By their numbers in this assay, from the lowest: compounds 3, 1 and 2 (each within the scatter of the next).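

In this assay, rearranging the same atoms from 2,4-difluorophenyl to 2,6-difluorophenyl on the amide-type nitrogen gives a number 10 percentage points lower from compound 2 to compound 3 (within the scatter) and setting 2,6-difluorophenyl in place of phenyl gives a number 5 percentage points lower from compound 1 to compound 3 (within the scatter) on the same read-out. Within the data shown here, this adds a second fluorine pattern to the first comparison at this position, and neither change leaves the scatter, so the three aryl groups on this nitrogen cannot be put in any order and the fluorine arrangement has no readable effect here. Nothing at hand bears on the reason for this result.

The compounds shown leave open whether any group on this nitrogen can move growth inhibition beyond the scatter, for example a cyclohexyl group, a longer alkyl chain, a pyridine ring or a phenyl ring carrying a methoxy group or a carboxylic acid. They also leave open whether the thiocarbonyl carbon matters to the read-out, as a carbonyl in its place would show, and whether the fluorine on the shared core does, as a chlorine or a hydrogen there would show.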